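From fluoro to methoxy with the benzyloxy group kept

The compounds below may be only part of what the source reports. "The series", "measured", "known", "first", "only" and "open" are said of these compounds alone.

Values in a functional assay on HCT-116 cells (Homo sapiens) for inhibition, read by sulforhodamine B assay, with a stated time of 3 days (a lower number here means a stronger inhibitor of growth, a higher number a weaker inhibitor of growth), follow:
Compound 1 `O=C(/C=C/c1ccccc1)c1ccc(OCc2ccccc2)cc1` gives > 50000 nM (a limit)
Compound 2 `O=C(/C=C/c1ccc(F)cc1)c1ccc(OCc2ccccc2)cc1` gives > 50000 nM (a limit)
Compound 3 `O=C(/C=C/c1ccc(F)cc1)c1ccccc1` gives 4360 nM (a number)

Compound 2 reads > 50000 nM here, which is a limit and not a number. This is the limit of > 50000 nM in this assay, at which 2 of the 3 values shown sit, and so offers no exact starting point. Compound 4 `COc1ccc(/C=C/C(=O)c2ccc(OCc3ccccc3)cc2)cc1` alters one group of compound 2: methoxy in place of fluoro on an aromatic carbon.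

Among the compounds with values here, two measured steps bear on this. At the same place, a step that the two limits leave unreadable from compound 1 to compound 2 tells nothing about size. The large one is an at least 11-fold lower number from compound 2 to compound 3 (1.05 log units; beyond the scatter) and it takes away the benzyloxy group. Compound 4 keeps that group, so it is expected to stay as weak a growth inhibitor as compound 2.

The expected result is a number no higher from compound 2 to compound 4 (the limit leaves the size open) with no clear direction, and another report at the limit is likely. Compound 4 is estimated at 50000 nM with an expected range of 20000 nM to 100000 nM in this assay when measured.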

Compound 4, concentration for 50% growth inhibition: 36900 nM
Compound 4: the middle estimate sits 1.4-fold (0.13 log units) above what was measured, within the range that was stated.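

In this assay, compound 4 is the first compound carrying the benzyloxy group to give an exact number, 36900 nM, so this group does not hold every compound shown beyond the reach of the assay. Compound 1 and compound 2 give only a limit, not a number: the limit of > 50000 nM in this assay, at which 2 of the 4 values shown sit. From the compounds shown here alone, putting methoxy in place of fluoro gives an at least 1.3-fold lower number from compound 2 to compound 4 (0.13 log units; that floor lies within the scatter), and putting methoxy in place of hydrogen gives an at least 1.3-fold lower number from compound 1 to compound 4 (0.13 log units; that floor lies within the scatter); both are only floors within the scatter, so the true size of each step remains unknown.

The compounds shown leave open whether another group at this position, such as an amine, a carboxylic acid or a longer chain, would shift the number further. They also leave open what methoxy gives with hydrogen in place of benzyloxy, the form in which compound 3, carrying fluoro, reads 4360 nM.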